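A few compounds are considered here, and "the series" means these few. Any claim that something is new, unique, unknown or untested is made for them only; others in the source may bear on it.

In a functional assay on MDA-MB-231 cells (Homo sapiens) for antiproliferative activity, read by MTT assay, with a stated time of 72 h (a lower number here means a stronger inhibitor, a higher number a weaker inhibitor), three compounds have been measured so far. Compound 1 `N#Cc1cccc(Nc2ccc3c(c2)S(=O)(=O)C=C3)c1` gives > 10000 nM, which is a limit of the assay and not a number. Compound 2 `O=S1(=O)C=Cc2cccc(Nc3ccc(OC(F)(F)F)cc3)c21` gives 2100 nM, and compound 3 `O=S1(=O)C=Cc2cccc(Nc3cccc(F)c3)c21` gives 1910 nM. These two numbers lie within the usual scatter of repeated measurements, so compound 2 stands level with compound 3 and no order can be drawn between them.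

The next compound, compound 4 `COc1ccc(Nc2cccc3c2S(=O)(=O)C=C3)cc1`, differs from compound 2 in one place: methyl in place of trifluoromethyl on an oxygen on an aromatic ring. Put simply, a trifluoromethoxy group becomes a methoxy group, with methyl in place of trifluoromethyl on an oxygen on an aromatic ring.

Among the measured compounds shown here, no measured pair of compounds shows this change or any other single change, so there is no direct precedent for its size. Compound 2 at 2100 nM and compound 3 at 1910 nM carry different groups yet sit within the scatter of each other, so no shift beyond the scatter is expected in this assay, and any drift would most likely be towards a slightly weaker compound. The expected change is a 1.2-fold higher number from compound 2 to compound 4 (0.08 log units; within the scatter). The data also include (the limit of > 10000 nM in this assay, at which 1 of the 3 values shown sits), so a result reported only as a limit remains possible for compound 4. For compound 4 the estimated value is 2500 nM, with an expected range from 900 nM to 7000 nM.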

Compound 4, half-maximal inhibitory concentration: 1040 nM
Estimate against measurement, compound 4: 2.4-fold (0.38 log units) above, within the range that was stated.
By their numbers in this assay, from the lowest: compounds 4, 3 and 2 (each within the scatter of the next, the first and the last beyond it). At a limit, above all of these: compound 1.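

In this assay, among the compounds shown here, the change from trifluoromethoxy to methoxy gives a 2.0-fold lower number from compound 2 to compound 4 (0.31 log units; beyond the scatter) and this is the first direct reading of a single change, as compounds 2 and 4 differ in one place only. The step is modest but lies beyond the scatter, so the group carried on this oxygen on an aromatic ring does affect the result, and of the two groups compared here, methyl gives the stronger inhibitor. The data shown include no measured property of either group, so they offer no explanation for this step.

For the compounds shown here, one pair gives only one step in one direction, so it remains open whether a longer chain on the oxygen, such as ethyl, would give a lower or a higher number than compound 4. Going by these compounds, it also remains open how a hydroxyl group, an amine or a carboxylic acid in this place would compare with the methoxy group of compound 4.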